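Oxidising the Sulfide Bridge of Compound 1

The source may hold more compounds than are shown below. What is called first, only, known or untested is meant among the compounds shown, and "the series" means these compounds.

Compound 1 `O=C(Nc1ccc(S(F)(F)(F)(F)F)cc1)c1ccc(Sc2ccc(O)cc2)cc1` gives 4860 nM in a functional assay on LNCaP cells (Homo sapiens) for antiproliferative activity, read by fluorescence and propidium iodide staining, with a stated time of 96 h (a higher number here means a weaker inhibitor, a lower number a stronger inhibitor), the lowest of the three numbers in hand. Compound 2 `O=C(Nc1ccc(C(F)(F)F)cc1)c1ccc(Sc2ccc(O)cc2)cc1` gives 8300 nM, and the step of a 1.7-fold higher number from compound 1 to compound 2 (0.23 log units; within the scatter) lies within the scatter. Compound 3 `O=C(Nc1cccc(C(F)(F)F)c1)c1ccc(Sc2cccc(C(F)(F)F)c2)cc1` gives 12500 nM, a number that sits beyond the scatter from compound 1. Compound 4 `O=C(Nc1ccc(S(F)(F)(F)(F)F)cc1)c1ccc([S+]([O-])c2ccc(O)cc2)cc1` differs from compound 1 in one place: a group of 9 heavy atoms (6 carbon, 2 oxygen, 1 sulfur; one six-membered aromatic ring of carbon only) in place of a group of 8 heavy atoms (6 carbon, 1 oxygen, 1 sulfur; one six-membered aromatic ring of carbon only), on an aromatic carbon. Going by the values given here, no measured step touches this part of the shared core; the one measured step concerns the other end of the molecule and stayed within the scatter. With nothing to point either way, compound 4 is expected to show a 1.1-fold higher number from compound 1 to compound 4 (0.05 log units; within the scatter) in this assay, no more than the scatter. Compound 4 is therefore estimated at 5500 nM, between 2200 nM and 14000 nM.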

Compound 4, half-maximal inhibitory concentration: 900 nM
Compound 4: the middle estimate sits 6.1-fold (0.79 log units) above what was measured, and the stated range ends above it.
By their numbers in this assay, from the lowest: compound 4; then compounds 1, 2 and 3 (each within the scatter of the next, the first and the last beyond it).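

The sulfur bridge of the shared core proves a responsive place: one added oxygen, turning the sulfide into a sulfoxide, gives a 5.4-fold lower number from compound 1 to compound 4 (0.73 log units; beyond the scatter) in this assay. Going by these compounds alone, this step lies beyond the scatter, whereas the only earlier step of a 1.7-fold higher number from compound 1 to compound 2 (0.23 log units; within the scatter) changed the other end of the molecule and stayed within it. No measurement at hand accounts for the gain. The compounds shown leave open how a sulfone or an ether oxygen at this bridge would compare, and whether the same added oxygen would lower the number for compound 2 as well.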